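The source may report more compounds than this note shows. Statements on the series, on what has been measured and on what is new or still open speak of the compounds shown alone.

Compound 1 `Cc1ccnc(OC(c2ccc(C(F)(F)F)cc2)C2CCN(C(C)CCNC(=O)c3c(Cl)cncc3Cl)CC2)c1` gives 33600 nM in an ADME assay on PBMC cells (Homo sapiens) for cytotoxicity; a lower number here means that less compound is tolerated, a higher number that more compound is tolerated.
Compound 2 `Cc1cccc(OC(c2ccc(Br)cc2)C2CCN(C(C)CCNC(=O)c3c(Cl)cncc3Cl)CC2)n1` gives 6500 nM in this assay.
Compound 3 `CC(CCNC(=O)c1c(Cl)cncc1Cl)N1CCC(C(Oc2cccc(Cl)n2)c2ccc(OC(F)(F)F)cc2)CC1` gives 6000 nM in this assay.

Of these three measured compounds, compound 1 stands at the highest number in this assay, and both other compounds sit well below it, further away than repeated measurements usually scatter. Compound 2 and compound 3 lie close to one another, so nothing can be said about an order between those two.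

The step goes from compound 1 to compound 4 `CC(CCNC(=O)c1c(Cl)cncc1Cl)N1CCC(C(Oc2ccccc2Cl)c2ccc(C(F)(F)F)cc2)CC1`, which has not yet been measured in this assay. The structural change is 2-chlorophenyl in place of 4-methylpyridin-2-yl on an oxygen on a saturated carbon. Among the measured compounds shown here, no step between two measured compounds tells how such a change behaves here, so the expectation rests only on where compound 1 stands relative to compound 2 and compound 3. Because compound 1 sits alone at the top with 33600 nM while compound 2 shows 6500 nM and compound 3 shows 6000 nM, a move back toward the lower numbers seems more likely than a further rise. A modest downward step, a 2.2-fold lower number from compound 1 to compound 4 (0.35 log units; beyond the scatter), is expected for compound 4, and its number in this assay is estimated at 15000 nM, within a range from 5000 nM to 40000 nM.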

Compound 4, half-maximal cytotoxic concentration: 4400 nM
Compound 4: middle estimate off by 3.4-fold (0.53 log units), on the high side; the measured number lies below the stated range.
By their numbers in this assay, from the lowest: compounds 4, 3 and 2 (each within the scatter of the next); then compound 1.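

Putting 2-chlorophenyl in place of 4-methylpyridin-2-yl on this oxygen gives a 7.6-fold lower number from compound 1 to compound 4 (0.88 log units; beyond the scatter) in this assay, so the aromatic group held here matters for how much compound the cells tolerate. The swap removes a ring nitrogen and a methyl and brings in a chlorine, all in one step, so this single comparison cannot show which of these changes drives the shift. Nothing measured here explains the step.

On these data alone, it remains open whether a plain phenyl ring, or a pyridine ring carrying an amine instead of the methyl, would sit nearer compound 1 or nearer compound 4. As far as these compounds go, it is equally open whether the same swap would give a similar step with a different group in place of the trifluoromethyl.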